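This account rests on a few compounds, and the source may have more. Where it says the series, first, only, none or still open, it means among the compounds named here.

Of the compounds shown here, three from this series have been measured in a functional assay on NCI-H460 cells (Homo sapiens) for cytotoxicity, read by MTT assay, with a stated time of 72 h (on this read-out lower numbers stand for stronger inhibition and higher numbers for weaker inhibition), and a fourth awaits its number. Compound 1 `CN(C)CCNc1nc(-c2ccc(NC(=O)Nc3ccc(Cl)cc3)cc2)nc2c(Cl)c(Cl)sc12` gives 300 nM in this assay. Compound 2 `CN(C)CCNc1nc(-c2ccc(NC(=O)Nc3ccc(Cl)cc3Cl)cc2)nc2c(Cl)c(Cl)sc12` carries one more chlorine than compound 1, the change being (chloro in place of hydrogen on an aromatic carbon), and in this assay compound 2 gives 1520 nM; the step is a 5.1-fold higher number from compound 1 to compound 2 (0.70 log units; beyond the scatter). Compound 3 `CCN(CC)CCNc1nc(-c2ccc(NC(=O)Nc3ccccc3Cl)cc2)nc2ccsc12` rests on a different core, and the difference between the two cores is not broken down here; in this assay compound 3 gives 320 nM, a number that sits within the scatter of compound 1.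

Compound 4 `CCN(CC)CCNc1nc(-c2ccc(NC(=O)Nc3ccc(Cl)cc3Cl)cc2)nc2ccsc12` is the not yet measured member. It differs from compound 3 by chloro in place of hydrogen on an aromatic carbon, which is the same kind of change as that from compound 1 to compound 2, though not the same: in compound 2 the entering chloro stands ortho to a large group and meta to a chloro group, whereas in compound 4 it stands meta to a chloro group and para to a large group. The only measured step of this kind is the one from compound 1 to compound 2, and it occurs twice among the compounds shown. On that single precedent, compound 4 is expected to show a 4.1-fold higher number from compound 3 to compound 4 (0.61 log units; beyond the scatter) in this assay, a step of roughly the same size as a 5.1-fold higher number from compound 1 to compound 2 (0.70 log units; beyond the scatter), because compound 3 gives 320 nM as its starting point. The estimate for compound 4 in this assay is 1300 nM, with a likely range from 450 nM to 3500 nM.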

Compound 4, half-maximal inhibitory concentration: 1890 nM
Compound 4: the middle estimate sits 1.5-fold (0.16 log units) below what was measured, and the stated range covers the measured number.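

In this assay the change from 2-chlorophenyl to 2,4-dichlorophenyl gives a 5.9-fold higher number from compound 3 to compound 4 (0.77 log units; beyond the scatter), and set beside the earlier step on the other core, it carries over in direction and in size: the same change on two cores in this assay, a 5.1-fold higher number (0.70 log units; beyond the scatter) from compound 1 to compound 2 and a 5.9-fold higher number (0.77 log units; beyond the scatter) from compound 3 to compound 4, 1.2-fold (0.07 log units) apart, within the scatter of two such steps. This shows that, in these two pairs, adding a chloro to a chlorophenyl urea raised the number by a similar amount on both cores, even though the two pairs also differ in their amine side chain and the chloro enters at a different place on the ring in each. It does not show that the step would hold on any third core or for a chloro entering elsewhere, and two pairs in a single cell assay say nothing about why the number rises.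

The compounds shown leave open whether the step would look the same if the entering group were a fluoro or a methoxy group instead of a chloro, or if the chloro entered a phenyl ring that carried no other chloro. They also leave open how a longer chain between the core and the amine, or a carboxylic acid in place of that amine, would change the numbers in this assay.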